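The source may report more compounds than this note shows. Statements on the series, on what has been measured and on what is new or still open speak of the compounds shown alone.

Of the compounds shown here, three have been tested in a functional assay on MCF7 cells (Homo sapiens) for cytotoxicity, read by MTT assay, with a stated time of 72 h; a higher number here means a weaker inhibitor of growth, a lower number a stronger inhibitor of growth. Compound 1 `CCCOC(=O)Nc1ccc([Se]C#N)cc1` gives 8000 nM, compound 3 `CCOC(=O)Nc1ccc([Se]C#N)cc1` gives 8900 nM, and compound 2 `O=C(Nc1ccc([Se][Se]c2ccc(NC(=O)OCc3ccc([N+](=O)[O-])cc3)cc2)cc1)OCc1ccc([N+](=O)[O-])cc1` gives 20600 nM. Compound 3 thus stands second highest of the three numbers: its gap to compound 1 lies within the scatter, while its gap to compound 2 lies beyond it. Compound 4 `CCCCOC(=O)Nc1ccc([Se]C#N)cc1` differs from compound 3 by ethyl in place of hydrogen on a saturated chain carbon, two bonds along the chain from an oxygen next to a carbonyl group. Going by the values given here, one measured step bears on this change, a 1.1-fold higher number from compound 1 to compound 3 (0.05 log units; within the scatter), which shortened the same chain by one carbon and stayed within the scatter. Lengthening the chain is therefore expected to behave alike, a 1.2-fold lower number from compound 3 to compound 4 (0.07 log units; within the scatter), with no movement beyond the scatter. Compound 4 is expected to give 7500 nM, within a range from 3500 nM to 16000 nM.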

Compound 4, concentration for 50% growth inhibition in the MCF7 assay: 6600 nM
For compound 4 the middle estimate is 1.1-fold (0.06 log units) above the measured one; low and high end bracket the measured number.
By their numbers in the MCF7 assay, from the lowest: compounds 4, 1 and 3 (each within the scatter of the next); then compound 2.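

In the MCF7 assay the step from ethoxy to butoxy gives a 1.3-fold lower number from compound 3 to compound 4 (0.13 log units; within the scatter), and the neighbouring chain gives a 1.2-fold lower number from compound 1 to compound 4 (0.08 log units; within the scatter), so the number stays level across these chain lengths. The same change does register elsewhere: in a physicochemical assay, with a stated time of 180 min, tested at 0.5 mg/mL (a higher number here means more inhibition at the concentration tested (going by the name of the read-out), a lower number less inhibition), compound 3 gives 37% and compound 4 gives 6.6%, a gap beyond the scatter. The two read-outs therefore need not follow each other at this position. From the compounds shown here alone, whether a longer chain, or a chain carrying an amine or a carboxylic acid, would move either number stays open.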